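Adding cyclopentyl to the lowest of three compounds

The source may report more compounds than this note shows. Statements on the series, on what has been measured and on what is new or still open speak of the compounds shown alone.

Values so far in an ADME assay on microsomes from liver (Rattus norvegicus) for metabolic stability, with a stated time of 60 min, tested at 1 uM; on this read-out lower numbers stand for a less stable compound and higher numbers for a more stable compound:
- compound 1 `CNc1nc2c(-c3ccnc(OC)c3)cnn2cc1OC` gives 74%
- compound 2 `COc1cc(-c2cnn3cc(OC)c(C4CCOC4)nc23)ccn1` gives 34%
- compound 3 `COc1cnc2c(-c3ccnc(OC)c3)cnn2c1` gives 10%

Compound 3 stands lowest of the three, and both other compounds lie clearly higher in this assay. Compound 4 `COc1cc(-c2cnn3cc(OC)c(C4CCCC4)nc23)ccn1` differs from compound 3 by a single change, (cyclopentyl in place of hydrogen on an aromatic carbon), which puts cyclopentyl in place of hydrogen on an aromatic carbon.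

The closest guide is compound 2, which carries oxolan-3-yl where compound 4 carries cyclopentyl. The modest a number 24 percentage points lower from compound 2 to compound 3 (beyond the scatter) shows what removing that ring did, and read backwards it suggests that adding a ring to compound 3 could raise the number. The large a number 64 percentage points lower from compound 1 to compound 3 (beyond the scatter) and a number 40 percentage points lower from compound 1 to compound 2 (beyond the scatter) both involve methylamino, which is absent from compound 4, so they say less here. For the measured compounds named here, no measured compound carries cyclopentyl, and one close comparison is thin support. A modest rise is expected, perhaps smaller than the gap between compound 3 and compound 2, and it may not clear the usual scatter. The expected change is a number 10 percentage points higher from compound 3 to compound 4 (within the scatter) in this assay as a best guess. Compound 4 is estimated at 20% with 6% and 42% as the expected lower and upper ends.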

Compound 4, percent of the compound remaining: 7%
Compound 4: middle estimate off by 13 percentage points, on the high side, and the stated range covers the measured number.
By their numbers in this assay, from the lowest: compounds 4 and 3 (each within the scatter of the next); then compound 2; then compound 1.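

In this assay, a cyclopentyl ring on this aromatic carbon leaves the compound indistinguishable from the one carrying only hydrogen there, with a number 3 percentage points lower from compound 3 to compound 4 (within the scatter) as the step, so adding a ring at this position does not by itself change the read-out. Ring identity does matter in this pair, since exchanging oxolan-3-yl for the carbon-only ring of the same size gives a number 27 percentage points lower from compound 2 to compound 4 (beyond the scatter) and shows that the higher number of compound 2 does not extend to every five-membered ring placed here. The exchange of methylamino for cyclopentyl gives a number 67 percentage points lower from compound 1 to compound 4 (beyond the scatter) and leaves methylamino with the highest number of the four groups compared at this position.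

Nothing shown here gives a measured reason why oxolan-3-yl and methylamino stand apart from cyclopentyl and hydrogen. As far as these compounds go, it remains open whether another amine, such as dimethylamino or morpholine, would keep the number of compound 1, and whether an open chain, such as a methoxyethyl group, would resemble oxolan-3-yl or cyclopentyl on the same core.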